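A few compounds are considered here, and "the series" means these few. Any claim that something is new, unique, unknown or untested is made for them only; others in the source may bear on it.

Compound 1 `Fc1cccc(F)c1Cn1ccc2nc(-c3ccccc3)nc-2c1` gives > 100000 nM in an ADME assay on MDBK cells (Bos taurus) for cytotoxicity; a lower number here means that less compound is tolerated, a higher number that more compound is tolerated
Compound 2 `COc1ccc(Cn2ccc3nc(-c4ccccc4)nc-3c2)cc1` gives > 100000 nM in this assay

Compound 2 stands at > 100000 nM in this assay as a limit of the assay and not a number. Compound 1 likewise shows > 100000 nM as a limit. Among the compounds with values here, the one measured step is a step that the two limits leave unreadable from compound 1 to compound 2 and so offers no size to carry forward. The whole of the evidence is the limit of > 100000 nM in this assay, at which 2 of the 2 values shown sit, and no number lies behind it.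

Compound 3 `Clc1cccc(Cn2ccc3nc(-c4ccccc4)nc-3c2)c1` brings 3-chlorophenyl in place of 4-methoxyphenyl on a saturated chain carbon bound to an aromatic nitrogen, a change that counts as 3-chlorophenyl in place of 4-methoxyphenyl on a saturated chain carbon bound to an aromatic nitrogen with the shared core untouched. No step beyond the usual scatter is expected in this assay and no direction can be named, so another limit is the likeliest report. This expectation rests on compound 2 at > 100000 nM as a limit and on nothing finer. The expected change is a number no higher from compound 2 to compound 3 (the limit leaves the size open) on this estimate. For compound 3 the estimated value is 100000 nM with an expected range from 40000 nM to 200000 nM in this assay.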

Compound 3, half-maximal cytotoxic concentration: > 100000 nM
Compound 3: no number, only a limit (the forecaster's own chance of this, stated with the estimate: 80%); the middle value lies on the limit itself.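

Compound 3, like compound 1 and compound 2, is reported only as a limit of the assay, so its steps from compound 2 and from compound 1 cannot be read. The compounds shown leave open where the half-maximal cytotoxic concentration of each lies in this assay, and whether the three phenyl groups differ there at all.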